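Sulfanyl linker in place of benzylamino on the diamino core

The source may hold more compounds than are shown below. What is called first, only, known or untested is meant among the compounds shown, and "the series" means these compounds.

Among the measured compounds shown here, compound 1 `COc1ccc(CNc2nc3cc(N)cc(N)c3nc2-c2ccccc2)cc1OC` and compound 2 `Nc1cc(N)c2nc(-c3ccccc3)c(NCc3ccc(F)cc3)nc2c1` are the two measured members. In a functional assay on 786-0 cells (Homo sapiens) for inhibition, read by sulforhodamine B assay, with a stated time of 48 h (on this read-out higher numbers stand for weaker inhibition of growth and lower numbers for stronger inhibition of growth), compound 1 gives 15500 nM. In this assay compound 2 gives 23400 nM; the step of a 1.5-fold higher number from compound 1 to compound 2 (0.18 log units; within the scatter) places it within the scatter of compound 1, so the two cannot be ordered. Compound 3 `Nc1cc(N)c2nc(-c3ccccc3)c(Sc3ccc(F)cc3)nc2c1` differs from compound 2 by (4-fluorophenyl)sulfanyl in place of (4-fluorobenzyl)amino on an aromatic carbon. For the measured compounds named here, the only measured step swaps the aryl ring on the benzyl carbon and leaves the linker untouched, so no measured step bears on this change. The step to compound 3 is therefore expected to be small, a 1.1-fold higher number from compound 2 to compound 3 (0.03 log units; within the scatter). Compound 3 is estimated at 25000 nM, within 8000 nM to 80000 nM.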

Compound 3, concentration for 50% growth inhibition: < 100000 nM
Compound 3: no number, only a limit; the forecaster's own chance of this, stated with the estimate: 15%; the middle value is on the limit's open side.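

In this assay compound 3 gives only a limit, < 100000 nM, and the step from compound 2 to compound 3 cannot be read. The compounds shown leave open whether (4-fluorophenyl)sulfanyl in place of (4-fluorobenzyl)amino changes growth inhibition at all.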